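The source may hold more compounds than are shown below. What is called first, only, known or untested is meant among the compounds shown, and "the series" means these compounds.

Measured so far in a functional assay on ACHN cells (Homo sapiens) for antiproliferative activity, read by sulforhodamine B assay; on this read-out higher numbers stand for weaker inhibition of growth and lower numbers for stronger inhibition of growth:
Compound 1 `O=C(/C=C/c1ccc(O)cc1)c1c(O)cccc1OCC1CCCCC1`: > 30000 nM
Compound 2 `O=C(/C=C/c1ccc(O)cc1)c1c(O)cccc1OCC1CCCC1`: 3510 nM

Compound 1 has only a limit, > 30000 nM, and not a number. Within the data shown here, that leaves compound 2, at 3510 nM, with the only true number in this assay, so it cannot yet be ranked within a spread of measured values.

Compound 3 `CCCCOc1cccc(O)c1C(=O)/C=C/c1ccc(O)cc1` is still to be measured. It differs from compound 2 at one place: propyl in place of cyclopentyl on a saturated chain carbon bound to an oxygen on an aromatic ring. The ring of compound 2 thus gives way to an open chain in compound 3.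

Among the measured compounds shown here, one measured step bears on this place: an at least 8.5-fold lower number from compound 1 to compound 2 (0.93 log units; beyond the scatter). It came from putting cyclopentyl in place of cyclohexyl, and it lies beyond the scatter, so changes here can matter. However, it swaps one ring for another and offers no direct measure of a ring giving way to an open chain. Only a slight drop, within the scatter, is therefore expected, and the expected change is a 1.4-fold lower number from compound 2 to compound 3 (0.15 log units; within the scatter). Compound 3 is estimated at 2500 nM, with an expected range of 700 nM to 10000 nM.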

Compound 3, concentration for 50% growth inhibition: > 30000 nM
Compound 3 was reported as a limit; the forecaster's own chance of this, stated with the estimate: 10%; middle value at least 12-fold (1.07 log units) away from the limit.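

In this assay, opening the ring of compound 2 into a chain matters far more than the earlier ring-for-ring swap alone could show: propyl in place of cyclopentyl gives an at least 8.5-fold higher number from compound 2 to compound 3 (0.93 log units; beyond the scatter). Compound 3 gives > 30000 nM, which is a limit of the assay and not a number, and the step between compound 1 and compound 3 cannot be read, as both values are limits. Cyclopentyl now stands out at this position, with both the larger ring and the open chain giving much higher numbers, and only compound 2 has a true value: the limit of > 30000 nM in this assay, at which 2 of the 3 values shown sit.

The change from cyclopentyl to propyl removes the ring and also takes away carbon atoms, and the compounds shown do not separate these two changes. On these data alone, a pentyl chain or a cyclobutyl group at this place could help tell them apart, and how much growth inhibition compound 1 and compound 3 actually retain remains unknown.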